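Methoxy for methylamino on the carbonyl carbon

A few compounds are considered here, and "the series" means these few. Any claim that something is new, unique, unknown or untested is made for them only; others in the source may bear on it.

In a functional assay on KB cells (Homo sapiens) for inhibition, read by sulforhodamine B assay, with a stated time of 72 h (on this read-out higher numbers stand for weaker inhibition of growth and lower numbers for stronger inhibition of growth), compound 1 (`CNC(=O)/C=C/c1ccncc1-c1ccc2ccccc2c1`) gives > 10000 nM, a limit of the assay and not a number. Compound 2 (`CCOC(=O)/C=C/c1ccncc1-c1ccc2[nH]ccc2c1`) gives > 10000 nM, likewise a limit. Compound 3 (`COC(=O)/C=C/c1ccncc1-c1ccc2ccccc2c1`) keeps the core of compound 1 and carries methoxy in place of methylamino on a carbonyl carbon. Compound 1 offers only (the limit of > 10000 nM in this assay, at which 2 of the 2 values shown sit), and no measured step sizes this change. The expected outcome in this assay is no shift beyond the scatter, with an expected a number no higher from compound 1 to compound 3 (the limit leaves the size open). The estimated value for compound 3 is 10000 nM, within a range of 3000 nM to 30000 nM.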

Compound 3, concentration for 50% growth inhibition: 6730 nM
Compound 3: the middle estimate sits 1.5-fold (0.17 log units) above what was measured, within the range that was stated.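

In this assay, going by these compounds alone, compound 3 holds the only value that is a number and not a limit, so methoxy in place of methylamino on a carbonyl carbon gives a reading inside the range of the assay. The change gives an at least 1.4-fold lower number from compound 1 to compound 3 (0.17 log units; that floor lies within the scatter), which alone does not establish a real shift at this position. Compound 1 is only a limit, so the true size of the step stays open: the limit of > 10000 nM in this assay, at which 2 of the 3 values shown sit.

Open, from the compounds shown here alone, is whether a carboxylic acid or a longer chain on the same carbonyl carbon would move the number beyond the scatter.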